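A few compounds are considered here, and "the series" means these few. Any claim that something is new, unique, unknown or untested is made for them only; others in the source may bear on it.

Three compounds built on one shared core have been examined in a functional assay on HEK293 cells (Homo sapiens) for cytotoxicity; a lower number here means that less compound is tolerated, a higher number that more compound is tolerated. Compound 1 `COc1ccc([C@H]2CC(=O)N(C(=O)c3ccccc3)C2)cc1OC1CCCC1` reaches only a limit of the assay in this assay, > 10000 nM, which is not a number. Compound 2 `COc1ccc([C@H]2CC(=O)N(c3ccc([S+](C)[O-])cc3)C2)cc1OC1CCCC1` gives a number in this assay, 7510 nM. Going by the values given here, the single change with two measured ends, an at least 1.3-fold lower number from compound 1 to compound 2 (0.12 log units; that floor lies within the scatter), is a step that stays within the scatter of repeated measurements. Compound 3 `COc1ccc([C@H]2CC(=O)N(c3cccc(NC(=O)C(C)=O)c3)C2)cc1OC1CCCC1` again yields only a limit in this assay, > 10000 nM. Compound 3 therefore stands where most of the values stand: the limit of > 10000 nM in this assay, at which 2 of the 3 values shown sit, so that only compound 2 reports a number at all.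

Compound 4 `COc1ccc([C@H]2CC(=O)N(c3cccc(NS(=O)(=O)c4c(F)cccc4F)c3)C2)cc1OC1CCCC1` differs from compound 3 in one place: (2,6-difluorophenyl)sulfonyl in place of acetylcarbonyl on a nitrogen on an aromatic ring. Among the compounds with values here, no measured step touches this position; the only step with two measured ends alters the group on the amide-type nitrogen in the ring and stays within the scatter. With nothing pointing to a shift in either direction, the expected step that the limit leaves unreadable from compound 3 to compound 4 is none beyond the scatter. Compound 4 is accordingly estimated at 12000 nM, with a range from 5000 nM to 30000 nM, and a good chance that this assay once more reports only a limit.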

Compound 4, half-maximal cytotoxic concentration: > 10000 nM
Compound 4 was reported as a limit; the forecaster's own chance of this, stated with the estimate: 60%; the middle value does not contradict the limit.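

No size can be read for the change from compound 3 to compound 4, as both give only a limit of the assay and not a number in this assay; they sit together at that limit: the limit of > 10000 nM in this assay, at which 3 of the 4 values shown sit. As far as these compounds go, whether (2,6-difluorophenyl)sulfonyl in place of acetylcarbonyl on this nitrogen shifts the half-maximal cytotoxic concentration at all remains open.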